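A Second Methoxy on the Lactam Styryl Core

The compounds below may be only part of what the source reports. "The series", "measured", "known", "first", "only" and "open" are said of these compounds alone.

Compound 1 `O=c1ccoc(/C=C/c2ccccc2)c1` and compound 2 `COc1ccc(/C=C/c2cc(=O)cco2)cc1` share a core; in a functional assay on OVCAR-3 cells (Homo sapiens) for inhibition, read by sulforhodamine B assay, with a stated time of 48 h (on this read-out higher numbers stand for weaker inhibition of growth and lower numbers for stronger inhibition of growth), compound 1 gives 546 uM, while compound 2 gives 328 uM. The change methoxy in place of hydrogen on an aromatic carbon produced a 1.7-fold lower number from compound 1 to compound 2 (0.22 log units; within the scatter). Compound 3 `COc1ccc(/C=C/C2CC=CC(=O)N2)cc1` rests on another core, and the difference between the two cores is not broken down here; in this assay compound 3 gives 787 uM. Compound 4 `COc1ccc(/C=C/C2CC=CC(=O)N2)cc1OC` is not yet measured. It differs from compound 3 by methoxy in place of hydrogen on an aromatic carbon, the same kind of change as from compound 1 to compound 2, but here the entering methoxy sits ortho to a methoxy group and meta to a group of 9 heavy atoms rather than para to that group. Because compound 3 gives 787 uM and the earlier step stayed within the scatter, compound 4 is expected to show a step of a 1.3-fold lower number from compound 3 to compound 4 (0.12 log units; within the scatter) in this assay. Compound 4 is thus estimated at 600 uM, between 300 uM and 1200 uM.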

Compound 4, concentration for growth inhibition (reported as GI): > 964 uM
Compound 4 ended at the assay's limit; the forecaster's own chance of this, stated with the estimate: 20%; middle value at least 1.6-fold (0.20 log units) away from the limit.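

In this assay compound 4 gives > 964 uM, which is a limit of the assay and not a number. Methoxy in place of hydrogen on an aromatic carbon, here ortho to a methoxy group, gave an at least 1.2-fold higher number from compound 3 to compound 4 (0.08 log units; that floor lies within the scatter). The two cores therefore show neither that this change carries over from one to the other nor that it fails to, and the comparison remains unresolved: the same change on two cores in this assay, a 1.7-fold lower number (0.22 log units; within the scatter) from compound 1 to compound 2 and an at least 1.2-fold higher number (0.08 log units; that floor lies within the scatter) from compound 3 to compound 4; the limit leaves it open whether they differ

The compounds shown leave open how an amine, a carboxylic acid or a longer chain on that aromatic carbon would read on either core. They also leave open how a methoxy entering ortho to a methoxy group would read on the core of compound 1.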